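Oral inhibition by chlorobenzylsulfanyl dihydropyrimidine carboxamides in rat

This account rests on a few compounds, and the source may have more. Where it says the series, first, only, none or still open, it means among the compounds named here.

In a functional assay on the whole organism (artery, strain albino) with Rattus norvegicus as the target, with a stated time of 360 min, at a dose of 10 mg/kg by the oral route (on this read-out higher numbers stand for more inhibition at the one dose given (going by the name of the read-out) and lower numbers for less inhibition), the measured compounds stand as follows: compound 1 `CC1=C(C(=O)Nc2ccc(Br)cc2)C(c2ccc(Cl)cc2Cl)N=C(SCc2ccccc2Cl)N1` gives 38.1%; compound 2 `CC1=C(C(=O)Nc2ccc(Br)cc2)C(c2ccc(Cl)cc2Cl)N=C(SCc2cccc(Cl)c2)N1` gives 20.6%; compound 3 `COc1ccc(C2N=C(SCc3ccccc3Cl)NC(C)=C2C(=O)Nc2ccc(Br)cc2)cc1` gives 20.6%.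

Compound 1 has the highest of the three numbers, and compound 2 and compound 3 sit level with each other at the digits given. The change from compound 1 to compound 2 is 3-chlorophenyl in place of 2-chlorophenyl on a saturated chain carbon bound to a sulfur, and it made the step of a number 17.5 percentage points lower from compound 1 to compound 2 (beyond the scatter). Compound 3 differs from compound 1 in its core by 4-methoxyphenyl in place of 2,4-dichlorophenyl on a saturated ring carbon, with the step of a number 17.5 percentage points lower from compound 1 to compound 3 (beyond the scatter).

Compound 4 `COc1ccc(C2N=C(SCc3cccc(Cl)c3)NC(C)=C2C(=O)Nc2ccc(Br)cc2)cc1` is not yet measured. It differs from compound 3 by 3-chlorophenyl in place of 2-chlorophenyl on a saturated chain carbon bound to a sulfur, the same change as that from compound 1 to compound 2. For compound 4 the expected step is a number 12.6 percentage points lower from compound 3 to compound 4 (beyond the scatter), a smaller fall than before, because compound 3 already starts from 20.6% and the read-out cannot go far below it. The estimate for compound 4 is 8%, expected between 0% and 20%.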

Compound 4, a percentage reported as inhibition, in the whole organism at one dose (the size of the read-out at that dose, not a potency): 39.7%
The estimate for compound 4 lay 31.7 percentage points below the measured number; measured number above the stated range.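

In this assay, 3-chlorophenyl in place of 2-chlorophenyl on a saturated chain carbon bound to a sulfur gave a number 19.1 percentage points higher from compound 3 to compound 4 (beyond the scatter), and 4-methoxyphenyl in place of 2,4-dichlorophenyl on a saturated ring carbon gave a number 19.1 percentage points higher from compound 2 to compound 4 (beyond the scatter). The chlorobenzyl change therefore did not carry from one core to the other, even in direction: the same change on two cores in this assay, a number 17.5 percentage points lower (beyond the scatter) from compound 1 to compound 2 and a number 19.1 percentage points higher (beyond the scatter) from compound 3 to compound 4, 36.6 percentage points apart, beyond the scatter of two such steps The methoxyphenyl change did not carry either, and these four compounds show that the two changes depend on each other, but not why they do or how either would behave on a further core: the same change on two cores in this assay, a number 17.5 percentage points lower (beyond the scatter) from compound 1 to compound 3 and a number 19.1 percentage points higher (beyond the scatter) from compound 2 to compound 4, 36.6 percentage points apart, beyond the scatter of two such steps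

As far as these compounds go, whether this reversal would persist with an unsubstituted benzyl on the sulfur remains open. So does the outcome with a carboxylic acid in place of the bromine on the amide's phenyl ring.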